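Repositioning chlorines on the dichlorophenyl ether of compound 2

This account rests on a few compounds, and the source may have more. Where it says the series, first, only, none or still open, it means among the compounds named here.

Measured compounds:
- compound 1 `CC(C)(C)c1ccc(OCCCON2C(N)=NC(N)=NC23CCSCC3)cc1`: 1 nM
- compound 2 `NC1=NC2(CCOCC2)N(OCCCOc2cccc(Cl)c2Cl)C(N)=N1`: 140 nM

In a functional assay on MDA-MB-231 cells (Homo sapiens) for antiproliferative activity, read by MTT assay, with a stated time of 72 h (on this read-out higher numbers stand for weaker inhibition and lower numbers for stronger inhibition), compound 2 gives 140 nM, the higher of the two numbers shown; compound 1 gives 1 nM, a gap beyond the scatter. Compound 3 `NC1=NC2(CCOCC2)N(OCCCOc2ccc(Cl)c(Cl)c2)C(N)=N1` is not yet measured. It differs from compound 2 in one place: 3,4-dichlorophenyl in place of 2,3-dichlorophenyl on an oxygen on a saturated carbon. Within the data shown here, no measured pair isolates this change, so the direction of a 2.3-fold lower number from compound 2 to compound 3 (0.37 log units; beyond the scatter) is an expectation only, and a modest lowering of the number is expected. Compound 3 is therefore estimated at 60 nM, within 10 nM to 400 nM.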

Compound 3, half-maximal inhibitory concentration: 590 nM
Compound 3: the middle estimate sits 9.8-fold (0.99 log units) below what was measured; measured number above the stated range.
By their numbers in this assay, from the lowest: compound 1; then compound 2; then compound 3.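

In this assay, rearranging the same atoms gives a 4.2-fold higher number from compound 2 to compound 3 (0.62 log units; beyond the scatter), so at this place the number depends on where the chlorines sit and not only on which atoms are present. For this pair, 2,3-dichlorophenyl gives stronger inhibition than 3,4-dichlorophenyl. Nothing available gives a reason for this step.

The compounds shown leave open how a phenyl carrying a single chlorine, or a methoxy group, would compare. They also leave open whether this step would hold on the core of compound 1.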